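A few compounds are considered here, and "the series" means these few. Any claim that something is new, unique, unknown or untested is made for them only; others in the source may bear on it.

Measured in an assay on isolated protein for inhibition of histone deacetylase 4 (Homo sapiens), read by fluorescence; on this read-out lower numbers stand for stronger inhibition and higher numbers for weaker inhibition:

compound 1, `Cc1ccc(C(=O)/C=C/c2ccc(/C=C/C(=O)NO)o2)cc1`: 1100 nM
compound 2, `O=C(CCCCCCC(=O)Nc1ccccc1C(=O)NO)Nc1ccccc1`: 550 nM
compound 3, `O=C(NO)c1ccc(/C=C/c2ccc(O)cc2)o1`: 57100 nM

Compound 1 sits in the lower part of the three numbers. Its nearest neighbour is compound 2, and the gap between the two lies within the usual scatter, so nothing is read into their order. Compound 3 is the furthest from compound 1, and that gap lies well beyond the scatter; compound 3 also carries the shared hydroxamic acid on a different core, so its number is not taken as a guide to small changes on the core of compound 1. Among the measured compounds shown here, no pair of measured compounds differs in one place only, so there is no measured single-point step to lean on.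

Compound 4, `O=C(/C=C/c1ccc(/C=C/C(=O)c2ccccc2)o1)NO`, differs from compound 1 in one place:

hydrogen in place of methyl on an aromatic carbon

A change of this kind, one carbon lost at the far end of the molecule, is expected to move the number little. The step from compound 1 is estimated as a 1.3-fold higher number from compound 1 to compound 4 (0.10 log units; within the scatter), that is, none beyond the scatter, with a slight lean toward a higher number. For compound 4 the estimate in this assay is 1400 nM, with a range of 500 nM to 4000 nM.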

Compound 4, half-maximal inhibitory concentration: 22800 nM
Beside the measured number, compound 4's estimate is 16-fold (1.21 log units) below it, outside the stated range (above it).
By their numbers in this assay, from the lowest: compounds 2 and 1 (each within the scatter of the next); then compound 4; then compound 3.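

In this assay, among the compounds shown here, the change from 4-methylphenyl to phenyl gives the first measured step between compounds that differ in one place, and it is large: a 21-fold higher number from compound 1 to compound 4 (1.32 log units; beyond the scatter). Only one carbon leaves, with no ring, hydrogen-bond donor, hydrogen-bond acceptor or net charge lost, yet the step lies well beyond the scatter, so this place on the six-membered aromatic ring, para to a large group, cannot be treated as indifferent to substitution on the core of compound 1. No available measurement accounts for the size of this step.

The compounds shown leave open whether the gain belongs to methyl specifically or would also come with other groups at this place, such as ethyl, methoxy, chlorine or an amine, which would show how far the number follows the group that stands there. Also open, going by these compounds, is whether the same replacement gives a step of similar size on any other core, since this single pair is the only one that carries it.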